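This account rests on a few compounds, and the source may have more. Where it says the series, first, only, none or still open, it means among the compounds named here.

In a functional assay on Raji cells (Homo sapiens) for inhibition, read by MTT assay, with a stated time of 96 h (a higher number here means that more compound is needed for the effect, a lower number that less compound is needed), compound 1 `CC(C)Cn1c(=O)n(C)c(=O)c2nc([S+]([O-])CCCO)c(Cc3cccc4ccccc34)nc21` gives 1990 nM. Compound 2 `CC(C)Cn1c(=O)n(C)c(=O)c2nc(C(=O)N(C)CCCO)c(Cc3cccc4ccccc34)nc21` reaches only the assay limit, > 10000 nM. Compound 3 `CC(C)Cn1c(=O)n(C)c(=O)c2nc(-c3c(CCCO)nnn3C)c(Cc3cccc4ccccc34)nc21` also stops at the limit, > 10000 nM.

For the measured compounds named here, compound 1 therefore holds the only real number in this set, since the other two values are limits (the limit of > 10000 nM in this assay, at which 2 of the 3 values shown sit). Compound 4 `COCCCCCc1nc2c(=O)n(C)c(=O)n(CC(C)C)c2nc1Cc1cccc2ccccc12` differs from compound 1 in a single place: a group of 7 heavy atoms (6 carbon, 1 oxygen; no ring) in place of a group of 6 heavy atoms (3 carbon, 2 oxygen, 1 sulfur; no ring), on an aromatic carbon. Two measured steps start from that same position on compound 1, an at least 5.0-fold higher number from compound 1 to compound 2 (0.70 log units; beyond the scatter) and an at least 5.0-fold higher number from compound 1 to compound 3 (0.70 log units; beyond the scatter), and both ran upward by at least a modest amount. The 5-methoxypentyl group resembles neither of those replacements, yet nothing in the set points downward. A rise beyond the scatter is therefore expected for compound 4, a 3.0-fold higher number from compound 1 to compound 4 (0.48 log units; beyond the scatter). Compound 4 is estimated at 6000 nM, within a range from 2000 nM to 30000 nM.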

Compound 4, half-maximal effective concentration: 5780 nM
For compound 4 the middle estimate is 1.0-fold (0.02 log units) above the measured one; measured number inside the range.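

At this position on the shared core, 5-methoxypentyl, with no hydrogen-bond donor and no ring, still gives a number short of the limit in this assay, with a 2.9-fold higher number from compound 1 to compound 4 (0.46 log units; beyond the scatter). A readable value here is thus not confined to the group that leaves compound 1. Against the two other groups only floors can be given, an at least 1.7-fold lower number from compound 3 to compound 4 (0.23 log units; that floor lies within the scatter) and an at least 1.7-fold lower number from compound 2 to compound 4 (0.23 log units; that floor lies within the scatter), neither of which shows a step beyond the scatter: the limit of > 10000 nM in this assay, at which 2 of the 4 values shown sit.

Open, from the compounds shown here alone, is how a plain hexyl chain, a 5-hydroxypentyl chain or an amine at this position would read in this assay.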